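The source may report more compounds than this note shows. Statements on the series, on what has been measured and on what is new or still open speak of the compounds shown alone.

For the measured compounds named here, in a functional assay on A-375 cells (Homo sapiens) for antiproliferative activity, read by MTT assay, with a stated time of 48 h (on this read-out higher numbers stand for weaker inhibition and lower numbers for stronger inhibition), compound 1 `CCCCCc1nc(N)n(CC(=O)Nc2ccccc2)c1-c1ccccc1Br` gives 26400 nM; its only measured neighbour, compound 2 `Nc1nc(CC2CCCC2)c(-c2ccccc2Br)n1CC(=O)Nc1ccccc1`, gives 24300 nM in this assay, within the scatter of it. Going by the values given here, the one recorded step, a 1.1-fold lower number from compound 1 to compound 2 (0.04 log units; within the scatter), came from cyclopentyl in place of butyl on a saturated chain carbon bound to an aromatic carbon. Compound 3 `CCCCCc1nc(N)n(CC(=O)Nc2ccc(C)cc2)c1-c1ccccc1Br` differs from compound 1 by methyl in place of hydrogen on an aromatic carbon. Among the compounds with values here, no measured step touches that six-membered aromatic ring of carbon only, so there is no direct guide; the single step available was within the scatter. The step for compound 3 is expected as a 1.1-fold lower number from compound 1 to compound 3 (0.04 log units; within the scatter), nothing beyond the scatter. Compound 3 is estimated at 24000 nM, between 8000 nM and 70000 nM.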

Compound 3, half-maximal inhibitory concentration: 4300 nM
Estimate against measurement, compound 3: 5.6-fold (0.75 log units) above; the whole stated range lies above it.
By their numbers in this assay, from the lowest: compound 3; then compounds 2 and 1 (each within the scatter of the next).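

Phenyl to 4-methylphenyl, with methyl on an aromatic carbon para to a large group, gives a 6.1-fold lower number from compound 1 to compound 3 (0.79 log units; beyond the scatter) in this assay and is the first step in the series beyond the scatter. This six-membered aromatic ring of carbon only therefore responds to a single added carbon, which the change at the saturated chain had not shown. Nothing measured here accounts for the change.

From the compounds shown here alone, whether an ethyl, methoxy or chlorine at this place would act like methyl stays open. So does whether methyl would give a similar step on compound 2.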